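Removing a trifluoromethyl from compound 2

The compounds below may be only part of what the source reports. "The series", "measured", "known", "first", "only" and "open" are said of these compounds alone.

Of the compounds shown here, three sharing one core have been measured in a functional assay on BT-549 cells (Homo sapiens) for inhibition, read by sulforhodamine B assay, with a stated time of 48 h; on this read-out lower numbers stand for higher toxicity in this test and higher numbers for lower toxicity in this test. Compound 1 `O=C(Nc1cccc(-n2cc(-c3ccncc3)c(-c3ccc(Cl)c(O)c3)n2)c1)Nc1ccc(Cl)c(Cl)c1` does not reach a number in this assay: compound 1 gives > 32500 nM, which is a limit of the test. Compound 3 `O=C(Nc1cccc(-n2cc(-c3ccncc3)c(-c3ccc(Cl)c(O)c3)n2)c1)Nc1cc(C(F)(F)F)cc(C(F)(F)F)c1` is the only one of the three with a measured number, and in this assay compound 3 gives 4110 nM. Compound 2 `COc1cc(-c2nn(-c3cccc(NC(=O)c4cccc(C(F)(F)F)c4)c3)cc2-c2ccncc2)ccc1Cl` likewise shows only a limit in this assay, and compound 2 gives > 50000 nM. Compound 2 therefore stands at the limit of > 50000 nM in this assay, at which 1 of the 3 values shown sits, and of the other two values shown, one further value is also a limit, namely (the limit of > 32500 nM in this assay, at which 1 of the 3 values shown sits), so two of the three results offer no number at all.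

Compound 4 `COc1cc(-c2nn(-c3cccc(NC(=O)c4ccccc4)c3)cc2-c2ccncc2)ccc1Cl` has not yet been measured. It differs from compound 2 in one place: hydrogen in place of trifluoromethyl on an aromatic carbon. Among the measured compounds shown here, no pair of measured compounds in this set differs in exactly one place, so there is no measured step to lean on. The step from compound 2 to compound 4 in this assay is expected to be a number no higher from compound 2 to compound 4 (the limit leaves the size open), that is, none beyond the usual scatter, with compound 4 most likely staying at the limit of the test as compound 2 does. Compound 4 is accordingly estimated to give 50000 nM, within a range from 20000 nM to 120000 nM.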

Compound 4, concentration lethal to 50% of the cells: > 100000 nM
Compound 4 gave a limit, no number; the forecaster's own chance of this, stated with the estimate: 70%; at least 2.0-fold (0.30 log units) between middle value and limit.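

In this assay, among the compounds shown here, compound 2 and compound 4 both end at limits of the test rather than at numbers, so no step between them can be read. The compounds shown leave open whether hydrogen in place of trifluoromethyl on an aromatic carbon changes the read-out at all.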